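A few compounds are considered here, and "the series" means these few. Any claim that something is new, unique, unknown or untested is made for them only; others in the source may bear on it.

Compound 1 `C=C[C@@](C)(/C=C/c1ccc(Nc2ccc(OC)c(F)c2)cc1)CCC=C(C)C`, compound 2 `C=C[C@@](C)(/C=C/c1ccc(Nc2ccc(F)c(F)c2)cc1)CCC=C(C)C` and compound 3 `C=C[C@@](C)(/C=C/c1ccc(Nc2cc(F)c(F)cc2F)cc1)CCC=C(C)C` share one core and differ only in a single aromatic group. In a functional assay on NALM-6 cells (Homo sapiens) for cytotoxicity, with a stated time of 72 h (on this read-out lower numbers stand for an effect already at smaller amounts and higher numbers for an effect only at larger amounts of compound), compound 1 gives > 43400 nM, which is a limit of the assay rather than a number. Compound 2 likewise reaches only the limit > 43400 nM. Compound 3 also stops at the limit > 43400 nM. The steps a step that the two limits leave unreadable from compound 1 to compound 2, a step that the two limits leave unreadable from compound 1 to compound 3 and a step that the two limits leave unreadable from compound 2 to compound 3 therefore cannot be read, because the limit of > 43400 nM in this assay, at which 3 of the 3 values shown sit, is where every value sits. Compound 4 `C=C[C@@](C)(/C=C/c1ccc(-c2cccc(Br)c2)cc1)CCC=C(C)C` is not yet measured; it differs from compound 2 by 3-bromophenyl in place of (3,4-difluorophenyl)amino on an aromatic carbon. Among the compounds with values here, no measured step bears on this change. Compound 4 is therefore expected to stay at the limit, with an estimate of 60000 nM spanning 20000 nM to 200000 nM. The expected step is a step that the limit leaves unreadable from compound 2 to compound 4, of no readable size.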

Compound 4, half-maximal effective concentration: > 43400 nM
Compound 4 gave a limit, no number (the forecaster's own chance of this, stated with the estimate: 80%); the middle value does not contradict the limit.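

The step from compound 2 to compound 4 cannot be read, because both compounds stop at a limit rather than a number: the limit of > 43400 nM in this assay, at which 4 of the 4 values shown sit. The compounds shown leave open which change, if any, would give a measurable value in this assay.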